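A few compounds are considered here, and "the series" means these few. Any claim that something is new, unique, unknown or untested is made for them only; others in the source may bear on it.

Series notes, values in an ADME assay on L6 cells (Rattus norvegicus) for cytotoxicity, read by resazurin assay, with a stated time of 72 h; a lower number here means a stronger inhibitor, a higher number a weaker inhibitor:

- Compound 1 `Cc1ccc(C(=O)NC(=O)c2ccccc2O)cc1`: 46 ug/mL
- Compound 2 `COC(=O)c1ccc(C(=O)NC(=O)c2ccccc2O)cc1`: 42 ug/mL

Among the compounds with values here, only two compounds have been measured so far, and their values cannot be separated. Compound 2 therefore stands level with compound 1 within the scatter of this assay.

The next compound is compound 3 `COc1ccc(C(=O)NC(=O)c2ccccc2O)cc1`, which has methoxy in place of methoxycarbonyl on an aromatic carbon, para to a large group: methoxy in place of methoxycarbonyl on an aromatic carbon.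

Within the data shown here, one measured step bears on this position. It is a 1.1-fold lower number from compound 1 to compound 2 (0.04 log units; within the scatter), with methoxycarbonyl in place of methyl on an aromatic carbon, and it lies within the scatter. Among the measured compounds shown here, no measured compound yet carries methoxy, so this single step is thin evidence. Exchanging these two groups at this position has so far left the number unmoved, so no shift beyond the scatter is expected, and no direction is favoured.

The expected change is a 1.0-fold higher number from compound 2 to compound 3 (0.02 log units; within the scatter).

For compound 3 the estimated value is 44 ug/mL, with an expected range of 22 ug/mL to 85 ug/mL.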

Compound 3, half-maximal inhibitory concentration: 39 ug/mL
Compound 3: middle estimate off by 1.1-fold (0.05 log units), on the high side; low and high end bracket the measured number.
By their numbers in this assay, from the lowest: compounds 3, 2 and 1 (each within the scatter of the next).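

In this assay, replacing methoxycarbonyl with methoxy on an aromatic carbon, para to a large group, gives a 1.1-fold lower number from compound 2 to compound 3 (0.03 log units; within the scatter) and stays within the scatter, even though the entering group has fewer heavy atoms, no double bond and one hydrogen-bond acceptor fewer than the group it replaces. Methoxy in place of methyl at the same position gives a 1.2-fold lower number from compound 1 to compound 3 (0.07 log units; within the scatter) and also stays within the scatter, so the position now holds three groups with values that cannot be separated, where the earlier compounds offered only a single comparison between two groups. Nothing measured here accounts for this flat result.

Going by these compounds, it remains open whether an amine, a carboxylic acid or a longer chain at this position would move the number beyond the scatter in this assay, since all three groups so far carry no net charge and no hydrogen-bond donor. On these data alone, whether changes elsewhere on the shared core would be equally silent also remains open, as all three compounds differ only at this one position.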